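Removing the Methyl from the Methoxy Group

The source may report more compounds than this note shows. Statements on the series, on what has been measured and on what is new or still open speak of the compounds shown alone.

Compound 1 `COc1cc(C)cc(-c2nn(CC#N)cc2-c2ccnc(-c3ccc(N(C)C)cc3)c2)c1` was tested in a functional assay on SN12C cells (Homo sapiens) for cytotoxicity, read by sulforhodamine B assay, with a stated time of 48 h, tested at 10 uM (a higher number here means a weaker effect of the compound at the concentration tested, a lower number a stronger effect), where compound 1 gives -8%. This is the lowest of the two numbers available. For the measured compounds named here, its nearest companion, compound 2 `COc1cc(C)cc(-c2nn(CC#N)cc2-c2ccc(-c3cccc(C(C)=O)c3)nc2)c1`, gives 18% in this assay, a number higher than that of compound 1 by more than the usual scatter; the two share a core but differ in several places at once, so no single step between them is counted.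

Compound 3 `Cc1cc(O)cc(-c2nn(CC#N)cc2-c2ccnc(-c3ccc(N(C)C)cc3)c2)c1` is compound 1 with one change: hydrogen in place of methyl on an oxygen on an aromatic ring. Going by the values given here, no pair of measured compounds shows what such a change does in this assay, so the expectation rests on compound 1 alone. Only a small step, if any, is expected from compound 1 to compound 3, a number 13 percentage points higher from compound 1 to compound 3 (beyond the scatter), most likely within the scatter of repeated measurements. Compound 3 is therefore expected to give about 5%, with a plausible range from -15% to 30%.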

Compound 3, a percentage reported as activity, at one concentration (the size of the read-out at that concentration, not a potency): -29%
Compound 3: the middle estimate sits 34 percentage points above what was measured, and the stated range ends above it.
By their numbers in this assay, from the lowest: compound 3; then compound 1; then compound 2.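

In this assay, going from methoxy to hydroxy on the aromatic ring gives a number 21 percentage points lower from compound 1 to compound 3 (beyond the scatter), and in this assay a lower number means a stronger effect at the concentration tested. For the compounds shown here, this is the first single change that can be read on its own, and it shows that this oxygen is not indifferent to a small edit: removing one methyl is enough to move the result beyond the scatter. Nothing available explains why the number falls.

Compound 3 alone cannot tell whether the hydroxy group itself matters or only the loss of the methyl. Also open, on these data alone, is how an amine in the same place, or a longer chain such as ethoxy, would read, and whether the same change would act alike in compound 2.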